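From fluoro to bromo in a growth assay

The source may hold more compounds than are shown below. What is called first, only, known or untested is meant among the compounds shown, and "the series" means these compounds.

In a functional assay on HT-29 cells (Homo sapiens) for inhibition, read by sulforhodamine B assay, with a stated time of 48 h (a lower number here means a stronger inhibitor of growth, a higher number a weaker inhibitor of growth), compound 1 (`CCOC(=O)c1nn(-c2ccc(Cl)cc2)c(-c2ccc(Br)cc2)c1CNC(C)(C)C`) gives > 511000 nM; > 476000 nM (2 entries), and both entries are limits of the assay, not numbers. Compound 2 (`CC(C)(C)NCc1c(C(=O)O)nn(-c2ccc(Cl)cc2)c1-c1ccc(F)cc1`) gives > 623000 nM, which is also a limit, so compound 2 has no exact value. Compound 3 (`CC(C)(C)NCc1c(C(=O)O)nn(-c2ccc(Cl)cc2)c1-c1ccc(Br)cc1`) carries bromo in place of fluoro on an aromatic carbon, turning 4-fluorophenyl into 4-bromophenyl. Within the data shown here, no measured step shows what this swap does. The expected step of an at least 1.1-fold lower number from compound 2 to compound 3 (0.06 log units; that floor lies within the scatter) is none beyond the usual scatter in this assay. Compound 3 is estimated at 540000 nM, with an expected range of 270000 nM to 700000 nM, and it will probably be reported as a limit again.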

Compound 3, concentration for 50% growth inhibition: > 542000 nM
Compound 3: a limit, no number; the forecaster's own chance of this, stated with the estimate: 85%; at least 1.0-fold (0.00 log units) between middle value and limit.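

Compound 2 and compound 3 both give only limits of the assay, not numbers, and no step can be read between them. The compounds shown leave open whether 4-bromophenyl in place of 4-fluorophenyl changes anything in this assay, and at what concentration any of them would inhibit growth.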